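Oxazole for methylthiophene: working notes on compound 3

The source may hold more compounds than are shown below. What is called first, only, known or untested is meant among the compounds shown, and "the series" means these compounds.

Two compounds in this series have numbers in an assay on isolated protein for inhibition of ubiquitin carboxyl-terminal hydrolase 7 (Homo sapiens), with stated times of 30 min and 2 h; on this read-out higher numbers stand for weaker inhibition and lower numbers for stronger inhibition. Compound 1 `Cc1ccc(-c2ccc(CN3CCC(O)(Cn4cnc5c(-c6ccc(CN)cc6)n(C)nc5c4=O)CC3)c(Cl)c2)s1` gives 101 nM in this assay, and compound 2 `Cn1nc2c(=O)n(CC3(O)CCN(Cc4ccc(-c5ccco5)cc4Cl)CC3)cnc2c1-c1ccc(CNC=O)cc1` gives 20.9 nM in this assay. Of the two numbers, compound 1 stands at the higher one; compound 2 sits well below it, and that gap is beyond the usual scatter. Compound 2 differs from compound 1 in more than one place, so the two values alone say nothing about any single change.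

Compound 3 `Cn1nc2c(=O)n(CC3(O)CCN(Cc4ccc(-c5cnco5)cc4Cl)CC3)cnc2c1-c1ccc(CN)cc1` has not been measured in this assay. It differs from compound 1 in one place: 1,3-oxazol-5-yl in place of 5-methylthiophen-2-yl on an aromatic carbon. Within the data shown here, no measured pair isolates this exchange. Compound 2 also carries a five-membered aromatic ring with one hetero atom on an aromatic carbon of a six-membered aromatic ring of carbon only, together with a second difference, and its 20.9 nM is the only hint that such a ring can go with a lower number. On that basis the expected step in this assay is modest and toward a lower number, a 2.0-fold lower number from compound 1 to compound 3 (0.31 log units; beyond the scatter), roughly at the edge of the scatter. Compound 3 is estimated at 50 nM in this assay, with an expected range from 15 nM to 170 nM.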

Compound 3, half-maximal inhibitory concentration: 71.6 nM
Beside the measured number, compound 3's estimate is 1.4-fold (0.16 log units) below it; the range from low to high includes it.
By their numbers in this assay, from the lowest: compound 2; then compounds 3 and 1 (each within the scatter of the next).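

In this assay, among these compounds, 1,3-oxazol-5-yl in place of 5-methylthiophen-2-yl on this aromatic carbon gives a 1.4-fold lower number from compound 1 to compound 3 (0.15 log units; within the scatter), the first reading that isolates a single change at this position. At this position, a five-membered aromatic ring with 2 hetero atoms and 5 heavy atoms therefore reads the same within the scatter as one with 1 hetero atom and 6 heavy atoms, so this exchange of ring, with the loss of the methyl group and the sulfur atom, does not separate the two compounds on this read-out. Nothing available explains this result.

Open, going by these compounds, is how this position responds to a pyridine ring, a plain phenyl ring, or an amine or a carboxylic acid in place of the five-membered ring. Among the compounds shown here, also open is how much of the value of compound 2, 20.9 nM, belongs to its furan-2-yl ring and how much to the formyl group on its aminomethyl nitrogen, as no single-place pair separates the two.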